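A few compounds are considered here, and "the series" means these few. Any claim that something is new, unique, unknown or untested is made for them only; others in the source may bear on it.

In a functional assay on KYSE-450 cells (Homo sapiens) for inhibition, read by MTT assay, with a stated time of 48 h (on this read-out lower numbers stand for stronger inhibition and higher numbers for weaker inhibition), three compounds have been measured: compound 1 (`C/C=C/C(=O)N(Cc1ccc(OC)c(OC)c1)c1cc(OC)c(OC)c(OC)c1`) gives 39100 nM, compound 2 (`C/C=C/C(=O)N(Cc1ccc(OC)c(C)c1)c1cc(OC)c(OC)c(OC)c1`) gives 32900 nM, and compound 3 (`C/C=C/C(=O)N(Cc1cccc(O)c1)c1cc(OC)c(OC)c(OC)c1`) gives 14700 nM, the lowest of the three numbers. Compound 4 (`C/C=C/C(=O)N(Cc1ccc(OC)c(F)c1)c1cc(OC)c(OC)c(OC)c1`) is the next to be tested, and it differs from compound 3 as follows: 3-fluoro-4-methoxyphenyl in place of 3-hydroxyphenyl on a saturated chain carbon bound to an amide-type nitrogen. Within the data shown here, two measured steps bear on this. Putting methyl in place of methoxy gave a 1.2-fold lower number from compound 1 to compound 2 (0.07 log units; within the scatter), so that swap shows no real change. Putting 3-hydroxyphenyl in place of 4-methoxy-3-methylphenyl gave a 2.2-fold lower number from compound 2 to compound 3 (0.35 log units; beyond the scatter), a modest drop. Compound 4 loses 3-hydroxyphenyl and gains 3-fluoro-4-methoxyphenyl, which roughly reverses that drop, so a modest rise is expected. The expected change is a 2.0-fold higher number from compound 3 to compound 4 (0.31 log units; beyond the scatter). For compound 4, the estimated value is 30000 nM, with an expected range of 15000 nM to 60000 nM.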

Compound 4, half-maximal inhibitory concentration: 1400 nM
Estimate against measurement, compound 4: 21-fold (1.33 log units) above, outside the stated range (below it).
By their numbers in this assay, from the lowest: compound 4; then compound 3; then compounds 2 and 1 (each within the scatter of the next).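

In this assay, fluoro in place of methyl gave [ a 24-fold lower number from compound 2 to compound 4 (1.37 log units; beyond the scatter) ], and fluoro in place of methoxy gave [ a 28-fold lower number from compound 1 to compound 4 (1.45 log units; beyond the scatter) ], so this aromatic carbon, where swapping methoxy for methyl showed no real change, responds strongly to fluoro. The 3-fluoro-4-methoxyphenyl group also beats 3-hydroxyphenyl on the saturated chain carbon bound to the amide-type nitrogen, with [ an 11-fold lower number from compound 3 to compound 4 (1.02 log units; beyond the scatter) ], so a hydroxyl is not needed for a low number here. Nothing available gives a cause for this gain.

On these data alone, whether chloro or a nitrile on that aromatic carbon would match fluoro remains open. So does whether a 3-fluorophenyl group, without the methoxy, would keep the gain.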